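The compounds below may be only part of what the source reports. "The series", "measured", "known", "first", "only" and "open" are said of these compounds alone.

Working notes on the series in an in vitro ADME assay on microsomes from liver (Homo sapiens) for metabolic stability, tested at 1 uM; a lower number here means slower removal, a higher number faster removal of the compound.

Compound 2 `Cc1cc(CCC#N)cc(C)c1Oc1cc(Nc2ccc(C#N)cc2)c(N)cc1CO` gives 330 mL.min-1.g-1. Compound 1 `CNC(=O)c1cc(N)c(Nc2ccc(C#N)cc2)cc1Oc1c(C)cc(CCC#N)cc1C` gives 120 mL.min-1.g-1; the change between the two, (methylcarbamoyl in place of hydroxymethyl on an aromatic carbon), made a step of a 2.8-fold lower number from compound 2 to compound 1 (0.44 log units; beyond the scatter). Compound 3 `Cc1cc(/C=C/C#N)cc(C)c1Oc1cc(Nc2ccc(C#N)cc2)c(N)cc1CO` gives 230 mL.min-1.g-1; its change from compound 2, (2-cyanoethenyl in place of 2-cyanoethyl on an aromatic carbon), made a step of a 1.4-fold lower number from compound 2 to compound 3 (0.16 log units; within the scatter), so the two are treated as indistinguishable here.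

Compound 4 `CNC(=O)c1cc(N)c(Nc2ccc(C#N)cc2)cc1Oc1c(C)cc(/C=C/C#N)cc1C` is not yet measured. It differs from compound 3 by methylcarbamoyl in place of hydroxymethyl on an aromatic carbon, and the place is described in the same words as for the pair above, so this is the same change, occurring twice among the compounds shown; the cores differ only by 2-cyanoethenyl in place of 2-cyanoethyl on an aromatic carbon.

Among the compounds with values here, the step from compound 3 to compound 4 is expected to be about a 2.6-fold lower number from compound 3 to compound 4 (0.41 log units; beyond the scatter), beside the earlier step of a 2.8-fold lower number from compound 2 to compound 1 (0.44 log units; beyond the scatter), because that earlier step and the value of compound 3, 230 mL.min-1.g-1, are the only evidence available; the estimate rests on a single precedent. On this basis compound 4 is expected to give about 90 mL.min-1.g-1, within a range of 45 mL.min-1.g-1 to 180 mL.min-1.g-1.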

Compound 4, intrinsic clearance in microsomes in the Homo sapiens assay: 150 mL.min-1.g-1
The estimate for compound 4 lay 1.7-fold (0.22 log units) below the measured number; measured number inside the range.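

In the Homo sapiens assay, there is a 1.5-fold lower number from compound 3 to compound 4 (0.19 log units; within the scatter), which falls within the scatter where the earlier step fell beyond it, yet the gap between the two steps lies within the scatter, so methylcarbamoyl in place of hydroxymethyl carries from one core to the other as far as two pairs can tell: the same change on two cores in the Homo sapiens assay, a 2.8-fold lower number (0.44 log units; beyond the scatter) from compound 2 to compound 1 and a 1.5-fold lower number (0.19 log units; within the scatter) from compound 3 to compound 4, 1.8-fold (0.25 log units) apart, within the scatter of two such steps. In the Homo sapiens assay, there is a 1.3-fold higher number from compound 1 to compound 4 (0.10 log units; within the scatter), which likewise agrees with the earlier step for 2-cyanoethenyl in place of 2-cyanoethyl, and neither step lies beyond the scatter: the same change on two cores in the Homo sapiens assay, a 1.4-fold lower number (0.16 log units; within the scatter) from compound 2 to compound 3 and a 1.3-fold higher number (0.10 log units; within the scatter) from compound 1 to compound 4, 1.8-fold (0.25 log units) apart, within the scatter of two such steps. Two pairs do not fix the size of the change, and the step on the core of compound 3 alone cannot be told from no change; in a physicochemical assay for lipophilicity, at pH 7.4 (on this read-out lower numbers stand for lower lipophilicity and higher numbers for higher lipophilicity), compound 3 gives 4.14 and compound 4 gives 4.12, with a number 0.02 log units lower from compound 3 to compound 4 (within the scatter).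

Going by these compounds, it remains open whether a carboxylic acid or a dimethylcarbamoyl group in place of hydroxymethyl would follow the same course. Also open, on these data alone, is whether the change holds on a core carrying a longer chain in place of 2-cyanoethyl.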